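This account rests on a few compounds, and the source may have more. Where it says the series, first, only, none or still open, it means among the compounds named here.

Measured compounds in a functional assay for inhibition, with Homo sapiens as the target; on this read-out higher numbers stand for weaker inhibition and lower numbers for stronger inhibition:
Compound 1 `Cc1ccc(-c2ccnc(Nc3cccc(N(C)C)c3)n2)s1`: 5700 nM
Compound 2 `Cc1cc(C)cc(Nc2nccc(-c3cc(C)oc3C)n2)c1`: 4100 nM
Compound 3 `CN(C)c1cccc(Nc2nccc(-c3cccs3)n2)c1`: 2400 nM

Compound 3 has the lowest of the three numbers in this assay. Its nearest neighbour is compound 2, whose value sits within the usual scatter of compound 3, so no order between those two can be read from the data. The gap to compound 1 is larger: a 2.4-fold lower number from compound 1 to compound 3 (0.38 log units; beyond the scatter), a modest step beyond the scatter, and it removes a methyl on the thiophene side of the molecule.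

Compound 4 `c1ccc(Nc2nccc(-c3cccs3)n2)cc1` has not yet been measured. It differs from compound 3 in one place: hydrogen in place of dimethylamino on an aromatic carbon.

Among the compounds with values here, only one step among the measured compounds is available, and it concerns a methyl on a different ring, not the dimethylamino on the aniline ring, so it bears on the new change only indirectly. Compound 2 carries two methyls on that ring instead of a dimethylamino, yet it also differs on the other aryl group, so its value offers no clean comparison. The data therefore give no direct guide, and the expectation for compound 4 is a small step, likely a somewhat higher number, with wide uncertainty: the estimated step is a 1.7-fold higher number from compound 3 to compound 4 (0.22 log units; within the scatter). For compound 4 in this assay the estimate is 4000 nM, between 1500 nM and 12000 nM.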

Compound 4, half-maximal inhibitory concentration: 31700 nM
Compound 4: the middle estimate sits 7.9-fold (0.90 log units) below what was measured; measured number above the stated range.
By their numbers in this assay, from the lowest: compounds 3, 2 and 1 (each within the scatter of the next, the first and the last beyond it); then compound 4.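

In this assay, within the data shown here, putting hydrogen in place of dimethylamino on the six-membered aromatic ring of carbon only gives a 13-fold higher number from compound 3 to compound 4 (1.12 log units; beyond the scatter), a large step where the one earlier step, a methyl change on the thiophene side, was modest. Among these compounds, this is the first clean reading on this ring, and it shows that the number depends strongly on what this aromatic carbon carries: with the other aryl group held as thiophene, losing the dimethylamino costs far more than the earlier compounds gave any sign of. Nothing shown explains why the step is so large, as no measurement of any kind bears on the result.

From the compounds shown here alone, what remains open is whether dimethylamino itself is needed or whether any group at this place would do, since compound 2, which carries two methyls on that ring, also differs on the other aryl group and cannot settle it. A methoxy, a chlorine, a primary amine or a morpholine on the same carbon would separate these readings, and the compounds shown say nothing about how such groups would fare.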